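The source may hold more compounds than are shown below. What is called first, only, known or untested is meant among the compounds shown, and "the series" means these compounds.

Compound 1 `CC1=C(C(=O)OCc2ccccc2)C(c2ccoc2)NC(=O)N1`: 1%
Compound 2 `CC1=C(C(=O)OCc2ccccc2)C(c2cccs2)NC(=O)N1`: 8%
Compound 3 `CC1=C(C(=O)OCc2ccccc2)C(c2ccsc2)NC(=O)N1`: 25%

All three were run in an assay on membranes from HeLa cells for displacement of a labelled ligand from adenosine receptor A3 (Homo sapiens), read by scintillation counting, with a stated time of 180 min, tested at 1 uM; a lower number here means less inhibition, a higher number more inhibition at the concentration tested (going by the name of the read-out). Compound 1 gives the lowest of the three numbers; its nearest neighbour is compound 2, a number 7 percentage points higher from compound 1 to compound 2 (within the scatter), and the furthest is compound 3, a number 24 percentage points higher from compound 1 to compound 3 (beyond the scatter). Between the other two, a number 17 percentage points higher from compound 2 to compound 3 (beyond the scatter). Compound 4 `CC1=C(C(=O)OC2CCC2)C(c2ccoc2)NC(=O)N1` differs from compound 1 in one place: cyclobutyl in place of benzyl on an oxygen next to a carbonyl group. Among the measured compounds shown here, every measured step changes the group on the saturated ring carbon and leaves the oxygen next to the carbonyl group untouched, so no measured step bears on this change. Compound 1 already sits at the bottom of the read-out, which leaves little room downward, and nothing measured supports a rise. Compound 4 is therefore expected to stay close to compound 1, a number 4 percentage points higher from compound 1 to compound 4 (within the scatter), with an estimate of 5% (range -5% to 20%).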

Compound 4, a percentage reported as inhibition, at one concentration (the size of the read-out at that concentration, not a potency): 1%
Estimate against measurement, compound 4: 4 percentage points above; measured number inside the range.
By their numbers in this assay, from the lowest: compounds 1, 4 and 2 (each within the scatter of the next); then compound 3.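

Among the compounds shown here, the ester oxygen is now probed for the first time: in this assay, with furan-3-yl held constant, cyclobutyl in place of benzyl gives no change at the digits printed from compound 1 to compound 4 (within the scatter). Both groups leave the number at the bottom of the read-out, so this furan-3-yl pair cannot separate them, and a six-membered aromatic ring at this place is not needed to give this low reading. Nothing available explains this result.

Open, going by these compounds, is whether cyclobutyl would hold or lower the reading when paired with thiophen-3-yl, the group of compound 3 at 25%. Also open, on these data alone, is how a longer chain or an amine on this oxygen would read.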